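A few compounds are considered here, and "the series" means these few. Any claim that something is new, unique, unknown or untested is made for them only; others in the source may bear on it.

Compound 3 `CC(=O)OCCOCn1cnc2c(Cl)nc(Cl)nc21` is one of three compounds examined in an ADME assay on L1210/0 cells (Mus musculus) for cytotoxicity, with a stated time of 48 h; a higher number here means a weaker inhibitor, a lower number a stronger inhibitor. Compound 1 `O=C1O/C(=C\Cn2cc(F)c(=O)[nH]c2=O)C(OCc2ccccc2)=C1OCc1ccccc1` gives 5100 nM in this assay, and compound 2 `O=C1OC(C(O)Cn2cc(F)c(=O)[nH]c2=O)C(OCc2ccccc2)=C1OCc1ccccc1` gives 140000 nM. Compound 3 gives 39300 nM, so its number is the second highest of the three: compound 2 lies above it and compound 1 lies below it, and both gaps run beyond the usual scatter. For the measured compounds named here, compound 1 and compound 2 share one core, while compound 3 rests on a different core, so no single-site step links it to either of them.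

Compound 4 `CC(=O)OCCOCn1cnc2c(Cl)nc(N)nc21` differs from compound 3 in one place (amino in place of chloro on an aromatic carbon). Going by the values given here, no step between measured compounds of this kind exists here, so the expectation rests only on compound 3 itself. Cytotoxicity for a compound of this type is expected to stay weak, with the number for compound 4 estimated to be near that of compound 3 or a little higher, the step from compound 3 to compound 4 being a 2.0-fold higher number from compound 3 to compound 4 (0.31 log units; beyond the scatter). Compound 4 is thus expected to give about 80000 nM, within a range from 20000 nM to 400000 nM.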

Compound 4, half-maximal inhibitory concentration: > 200000 nM
Compound 4 gave a limit, no number; the forecaster's own chance of this, stated with the estimate: 30%; middle value at least 2.5-fold (0.39 log units) away from the limit.
By their numbers in this assay, from the lowest: compound 1; then compound 3; then compound 2. At a limit, above all of these: compound 4.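

Placing amino in place of chloro on the aromatic carbon between two ring nitrogen atoms gives an at least 5.0-fold higher number from compound 3 to compound 4 (0.70 log units; beyond the scatter), the first single-site step in this set, and it shows that this assay responds to a change at this position. Within this pair, chloro goes with the stronger inhibitor and amino with the weaker one. The reading for compound 4 is a limit and not a number, so the step has a lower bound only: the limit of > 200000 nM in this assay, at which 1 of the 4 values shown sits.

The compounds shown leave open whether the step follows the loss of chloro or the entry of amino, and how a methyl, methoxy or fluoro group would read at this position. They also leave open whether the same change would give a similar step with a hydroxyl group in place of the acetate ester.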